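This account rests on a few compounds, and the source may have more. Where it says the series, first, only, none or still open, it means among the compounds named here.

Compound 1 `CS(=O)(=O)Nc1ccc2c(c1)S(=O)(=O)C=C(c1c(O)c3c(Cl)cccc3n(Cc3ccc(F)cc3)c1=O)N2`: > 50000 nM
Compound 2 `CS(=O)(=O)Nc1ccc2c(c1)S(=O)(=O)C=C(c1c(O)c3ccc(F)cc3n(Cc3ccc(F)cc3)c1=O)N2`: > 50000 nM
Compound 3 `CS(=O)(=O)Nc1ccc2c(c1)S(=O)(=O)C=C(c1c(O)c3cc(F)ccc3n(Cc3ccccc3)c1=O)N2`: > 50000 nM

Of the compounds shown here, three built on a shared core have been tested in an ADME assay on 2209-23 cells (Homo sapiens) for cytotoxicity, read by WST assay; on this read-out lower numbers stand for higher toxicity in this test and higher numbers for lower toxicity in this test. Compound 1 gives > 50000 nM, which is a limit of the test rather than a measured number. Compound 2 likewise gives > 50000 nM, again a limit. Compound 3 gives > 50000 nM, also a limit. All three results sit at the limit of > 50000 nM in this assay, at which 3 of the 3 values shown sit, so compound 3 cannot be placed higher or lower than compound 1 or compound 2 in this assay; none of the three reached a concentration at which cell damage was seen.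

Compound 4 `CS(=O)(=O)Nc1ccc2c(c1)S(=O)(=O)C=C(c1c(O)c3cc(F)ccc3n(Cc3ccc(F)c(Cl)c3)c1=O)N2` has not yet been measured. It differs from compound 3 in one place: 3-chloro-4-fluorophenyl in place of phenyl on a saturated chain carbon bound to an aromatic nitrogen. Among the three measured compounds no pair differs in a single spot, so no measured step exists that could show what such a change does to cytotoxicity. Going by the values given here, with every value so far at the same limit, the expected step that the limit leaves unreadable from compound 3 to compound 4 is none beyond the usual scatter, and the most likely outcome is that the test again reports only its limit. Compound 4 is therefore estimated at 60000 nM, with a range from 20000 nM to 150000 nM.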

Compound 4, half-maximal cytotoxic concentration: > 50000 nM
Compound 4: a limit, no number; the forecaster's own chance of this, stated with the estimate: 85%; the middle value lies beyond the limit too.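

No step can be read from compound 3 to compound 4, because both results are limits of the test and not numbers: the limit of > 50000 nM in this assay, at which 4 of the 4 values shown sit.

The compounds shown leave open how far apart they truly lie in cytotoxicity, and what the change from benzyl to 3-chloro-4-fluorobenzyl does to it.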